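This account rests on a few compounds, and the source may have more. Where it says the series, first, only, none or still open, it means among the compounds named here.

Compound 1 `CC[C@H]1OC(=O)O[C@@]1(C)[C@@H]1OC(=O)[C@H](C)[C@@H](O)[C@H](C)[C@@H](O[C@@H]2O[C@H](C)C[C@H](N(C)C)[C@H]2OC(C)=O)[C@@]2(C)C[C@@H](C)[C@H](O2)[C@@H]1C`: 55.7 uM
Compound 2 `CC[C@@H]1O[C@@]1(C)[C@@H]1OC(=O)[C@H](C)[C@@H](O[C@H]2C[C@@](C)(OC)[C@@H](O)[C@H](C)O2)[C@H](C)[C@@H](O[C@@H]2O[C@H](C)C[C@H](N(C)C)[C@H]2O)[C@@]2(C)C[C@@H](C)[C@H](O2)[C@@H]1C`: 10.2 uM
Compound 3 `CC[C@H]1OC(=O)O[C@@]1(C)[C@@H]1OC(=O)[C@H](C)C(=O)[C@H](C)[C@@H](O[C@@H]2O[C@H](C)C[C@H](N(C)C)[C@H]2OC(C)=O)[C@@]2(C)C[C@@H](C)[C@H](O2)[C@@H]1C`: 27.9 uM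

All three were tested in a functional assay on THP-1 cells (Homo sapiens), read by MTT assay, with a stated time of 4 days; on this read-out higher numbers stand for an effect only at larger amounts of compound and lower numbers for an effect already at smaller amounts. Compound 2 gives the lowest number of the three, with compound 3 and compound 1 both higher by more than the scatter. Compound 4 `CO[C@]1(C)C[C@H](O[C@H]2[C@H](C)[C@@H](O[C@@H]3O[C@H](C)C[C@H](N(C)C)[C@H]3O)[C@@]3(C)C[C@@H](C)[C@H](O3)[C@H](C)[C@H](C(C)=O)OC(=O)[C@@H]2C)O[C@@H](C)[C@@H]1O` differs from compound 2 at one place: a group of 3 heavy atoms (2 carbon, 1 oxygen; no ring) in place of a group of 6 heavy atoms (5 carbon, 1 oxygen; one three-membered non-aromatic ring with 1 hetero atom), on a saturated ring carbon. Acetyl replaces the group carrying the three-membered ring, on a saturated ring carbon next to the ring oxygen. For the measured compounds named here, no measured pair isolates a single change, so the data give no direct guide to this one. In this assay, a small rise in the number is expected, since compound 2 at 10.2 uM is already the lowest. The estimated change is a 1.8-fold higher number from compound 2 to compound 4 (0.25 log units; within the scatter). For compound 4 the estimate is 18 uM, with an expected range from 7 uM to 45 uM.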

Compound 4, concentration for half-maximal effect: 12.3 uM
The estimate for compound 4 lay 1.5-fold (0.17 log units) above the measured number, within the range that was stated.
By their numbers in this assay, from the lowest: compounds 2 and 4 (each within the scatter of the next); then compounds 3 and 1 (each within the scatter of the next).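

In this assay there is now a step that isolates one place, a 1.2-fold higher number from compound 2 to compound 4 (0.08 log units; within the scatter), so the two compounds cannot be told apart. At this saturated ring carbon next to the ring oxygen, the group carrying the three-membered ring can therefore give way to acetyl, with its smaller heavy-atom count and no ring, without a shift beyond the scatter. No measurement bears on why this is so. Going by these compounds, whether an amine, a carboxylic acid or a longer chain on this carbon would give a similar number remains open.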